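Changing the Phenyl Group on Compound 2

The compounds below may be only part of what the source reports. "The series", "measured", "known", "first", "only" and "open" are said of these compounds alone.

Measured so far in a functional assay on HMEC-1 cells (Homo sapiens) for antiproliferative activity, read by cell counting, with a stated time of 4 days; on this read-out higher numbers stand for weaker inhibition and lower numbers for stronger inhibition:
- compound 1 `COc1ccc(Oc2ccccc2NC(C)=C2C(=O)CC(c3ccccc3)CC2=O)cc1OC`: 140 nM
- compound 2 `CC(Nc1ccccc1Oc1ccccc1)=C1C(=O)CC(c2ccccc2)CC1=O`: 160 nM

Within the data shown here, only two numbers are available so far. Compound 2, at 160 nM, stands level with compound 1 within the usual scatter of this kind of measurement.

The next molecule is compound 3 `COc1cc(Oc2ccccc2NC(C)=C2C(=O)CC(c3ccccc3)CC2=O)ccc1N`. It has 4-amino-3-methoxyphenyl in place of phenyl on an oxygen on an aromatic ring, and the count of that change reads (4-amino-3-methoxyphenyl in place of phenyl on an oxygen on an aromatic ring).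

Among the measured compounds shown here, one measured step bears on this place in the molecule: a 1.1-fold higher number from compound 1 to compound 2 (0.06 log units; within the scatter). There, phenyl replaced 3,4-dimethoxyphenyl on the same oxygen, and the number in this assay stayed within the scatter. That single step suggests this position tolerates a change of ring substituents. However, no measured compound carries an amino group, so the evidence is thin and the range must stay wide.

No change beyond the scatter is expected, in either direction, and the estimated step is a 1.1-fold lower number from compound 2 to compound 3 (0.03 log units; within the scatter). The expected value for compound 3 is 150 nM, with an estimated range from 50 nM to 450 nM.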

Compound 3, half-maximal inhibitory concentration: 29 nM
Compound 3: middle estimate off by 5.2-fold (0.71 log units), on the high side; measured number outside the range, below it.
By their numbers in this assay, from the lowest: compound 3; then compounds 1 and 2 (each within the scatter of the next).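

The swap of 3,4-dimethoxyphenyl for phenyl had left the number within the scatter, so the ring on this oxygen looked insensitive to its substituents, yet the new ring gives a 5.5-fold lower number from compound 2 to compound 3 (0.74 log units; beyond the scatter) and shows that this assay does respond to what this ring carries. The closer comparison is a 4.8-fold lower number from compound 1 to compound 3 (0.68 log units; beyond the scatter) in a pair that differs in a single place, amino in place of methoxy on an aromatic carbon, which ties the lower number to that one swap and shows that a small change on this ring can be enough. No measurement of any property of these compounds is at hand to explain why this swap lowers the number.

The compounds shown leave open whether the amino group does this on its own or only together with the methoxy group on the same ring, a question that a 4-aminophenyl ring would address. They also leave open how related groups would behave in the amino group's place, such as hydroxy, dimethylamino or acetylamino.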